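Exchanging the Aryl Group on the Ring Amine Nitrogen

The source may report more compounds than this note shows. Statements on the series, on what has been measured and on what is new or still open speak of the compounds shown alone.

Compound 2 `Nc1scc(CN2CCN(c3cccnc3)CC2)c1C(=O)c1ccc(Cl)cc1` was tested in a functional assay on CHO cells with adenosine receptor A1 (Homo sapiens) as the target, read by cAMP accumulation and immunoassay, with a stated time of 6 min, tested at 10 uM (on this read-out lower numbers stand for a stronger effect and higher numbers for a weaker effect at the one concentration tested), and gives -23%. On the numbers shown it stands highest of the three: compound 1 `COc1ccc(N2CCN(Cc3csc(N)c3C(=O)c3ccc(Cl)cc3)CC2)cc1` gives -52%, and compound 3 `Nc1scc(CN2CCN(c3cccc(F)c3)CC2)c1C(=O)c1cccc(C(F)(F)F)c1` gives -62%. For the measured compounds named here, the single measured step between compounds differing in one place is a number 29 percentage points higher from compound 1 to compound 2 (beyond the scatter), a modest shift toward a weaker effect when pyridin-3-yl takes the place of 4-methoxyphenyl.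

Compound 4 `Nc1scc(CN2CCN(c3cc(F)ccc3F)CC2)c1C(=O)c1ccc(Cl)cc1` differs from compound 2 by 2,5-difluorophenyl in place of pyridin-3-yl on an amine nitrogen in a ring. The step from compound 1 to compound 2 bears on this change in reverse: there, moving from a carbon-only aromatic ring to pyridin-3-yl raised the number, so a return to a carbon-only ring is expected to lower it, although 2,5-difluorophenyl is not 4-methoxyphenyl, and compound 3, which carries a fluorinated carbon-only ring on that nitrogen, also differs in its ketone aryl. A step of a number 27 percentage points lower from compound 2 to compound 4 (beyond the scatter) is therefore expected, toward a stronger effect. Compound 4 is estimated at -50%, with a range from -75% to -20%.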

Compound 4, a percentage reported as activity, at one concentration (the size of the read-out at that concentration, not a potency): -80%
Estimate against measurement, compound 4: 30 percentage points above; the whole stated range lies above it.
By their numbers in this assay, from the lowest: compound 4; then compounds 3 and 1 (each within the scatter of the next); then compound 2.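

In this assay the aryl group on the ring amine nitrogen now has three members on an otherwise unchanged structure, and the largest shift so far is a number 57 percentage points lower from compound 2 to compound 4 (beyond the scatter) in the direction of a stronger effect. The two carbon-only rings also differ from each other, with a number 28 percentage points lower from compound 1 to compound 4 (beyond the scatter) on the same side, so the read-out at this position does not depend only on whether the ring holds a nitrogen. Nothing measured here accounts for either step.

The compounds shown leave open whether chlorine atoms in place of the two fluorines, or a cyclohexyl group on that nitrogen, would keep this read-out. They also leave open whether the step to 2,5-difluorophenyl would hold with the ketone aryl of compound 3.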